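Ring expansion on the amide side chain of compound 2

This account rests on a few compounds, and the source may have more. Where it says the series, first, only, none or still open, it means among the compounds named here.

In a functional assay on HEK293 cells for antagonist activity at P2X purinoceptor 7 (Homo sapiens) (a higher number here means a weaker inhibitor, a lower number a stronger inhibitor), compound 2 `O=C(NCC1(O)CCCC1)c1cc(-c2ncc(F)cn2)ccc1Cl` gives 449 nM, the higher of the two numbers recorded; compound 1 `Cc1cnc(-c2ccc(Cl)c(C(=O)NCC3(O)CCCCCC3)c2)nc1` gives 8 nM, and the gap between them lies beyond the scatter, though the two compounds differ in more than one place. Compound 3 `O=C(NCC1(O)CCCCCC1)c1cc(-c2ncc(F)cn2)ccc1Cl` carries 1-hydroxycycloheptyl in place of 1-hydroxycyclopentyl on a saturated chain carbon bound to an amide-type nitrogen. Among the compounds with values here, no measured pair isolates this change, but compound 1, which carries the same seven-membered ring, gives 8 nM, so a sizeable move toward a lower number is expected. Compound 3 is estimated at 35 nM (range 8 nM to 150 nM), a step of a 13-fold lower number from compound 2 to compound 3 (1.11 log units; beyond the scatter) in this assay.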

Compound 3, half-maximal inhibitory concentration: 16 nM
Estimate against measurement, compound 3: 2.2-fold (0.34 log units) above; measured number inside the range.
By their numbers in this assay, from the lowest: compounds 1 and 3 (each within the scatter of the next); then compound 2.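

In this assay, within the data shown here, 1-hydroxycycloheptyl in place of 1-hydroxycyclopentyl gives a 28-fold lower number from compound 2 to compound 3 (1.45 log units; beyond the scatter) with nothing else altered, so ring size at this position matters on its own, which the earlier compounds could not show. With the seven-membered ring present, fluoro in place of methyl on an aromatic carbon gives a 2.0-fold higher number from compound 1 to compound 3 (0.30 log units; within the scatter) and so has no clear effect on this read-out. Nothing measured here explains the size of the ring effect. Still open, on these data alone, is where 1-hydroxycyclohexyl would fall, and whether an amine could replace the hydroxyl group on the ring.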